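Urea aryl swap: dichlorophenyl to trifluoromethylphenyl

The source may report more compounds than this note shows. Statements on the series, on what has been measured and on what is new or still open speak of the compounds shown alone.

In a functional assay on RPMI-8226 cells (Homo sapiens) for inhibition, read by sulforhodamine B assay, with a stated time of 48 h (a higher number here means a weaker inhibitor, a lower number a stronger inhibitor), compound 3 `COc1cc(Cl)cc(-c2nn(-c3cccc(NC(=O)Nc4ccc(Cl)c(Cl)c4)c3)cc2-c2ccncc2)c1` gives 650 nM, the highest of the three numbers shown. Compound 1 `COc1cc(Cl)cc(-c2nn(-c3cccc(NC(=O)Nc4ccc(Cl)c(C(F)(F)F)c4)c3)cc2-c2ccncc2)c1` gives 400 nM in this assay, a gap within the scatter, while compound 2 `COc1cc(Cl)cc(-c2nn(-c3cccc(NC(=O)Nc4cc(C(F)(F)F)cc(C(F)(F)F)c4)c3)cc2-c2ccncc2)c1` gives 240 nM, a gap beyond the scatter. Compound 4 `COc1cc(Cl)cc(-c2nn(-c3cccc(NC(=O)Nc4cccc(C(F)(F)F)c4)c3)cc2-c2ccncc2)c1` carries 3-(trifluoromethyl)phenyl in place of 3,4-dichlorophenyl on an amide-type nitrogen. Within the data shown here, the only measured step bearing on this change is a 1.6-fold higher number from compound 1 to compound 3 (0.21 log units; within the scatter), which runs the opposite way and lies within the scatter; compound 4 additionally drops the second chloro, and no measured pair isolates that loss. Compound 4 is therefore expected to sit close to compound 1 at 400 nM. The expected step is small, a 1.4-fold lower number from compound 3 to compound 4 (0.16 log units; within the scatter). Compound 4 is estimated at 450 nM in this assay, with a range of 200 nM to 1000 nM.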

Compound 4, half-maximal inhibitory concentration: 430 nM
For compound 4 the middle estimate is 1.0-fold (0.02 log units) above the measured one, within the range that was stated.
By their numbers in this assay, from the lowest: compounds 2, 1, 4 and 3 (each within the scatter of the next, the first and the last beyond it).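

Replacing the aryl group on the amide-type nitrogen with 3-(trifluoromethyl)phenyl gives a 1.5-fold lower number from compound 3 to compound 4 (0.18 log units; within the scatter) in this assay. Loss of one substituent from the urea aryl ring is also tolerated within the scatter: removing chloro gives a 1.1-fold higher number from compound 1 to compound 4 (0.03 log units; within the scatter) and removing one trifluoromethyl gives a 1.8-fold higher number from compound 2 to compound 4 (0.25 log units; within the scatter), so neither the chloro nor the second trifluoromethyl is shown to be needed here. No available evidence explains these steps.

Still open is whether any substituent on this ring is needed, since the plain phenyl group is not among the compounds shown. Also open, going by these compounds, is how an amine or a carboxylic acid would fare in place of trifluoromethyl.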